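Thiazole substituent swap: bromo for cyclopropyl

A few compounds are considered here, and "the series" means these few. Any claim that something is new, unique, unknown or untested is made for them only; others in the source may bear on it.

Among the measured compounds shown here, compound 2 `C[C@@H]1CN(c2sc(C3CC3)nc2-c2nc3ccccc3[nH]2)CCN1C(=O)Cn1cnc2cccnc21` gives 994 nM in an assay on blood for inhibition of C-X-C chemokine receptor type 3 (Homo sapiens), with a stated time of 30 min (a lower number here means a stronger inhibitor, a higher number a weaker inhibitor), the higher of the two numbers measured so far. For the measured compounds named here, its nearest neighbour is compound 1 `C[C@@H]1CN(c2scnc2-c2nc3ccccc3[nH]2)CCN1C(=O)Cn1cnc2cccnc21`, which gives 554 nM in this assay; the only measured step, a 1.8-fold higher number from compound 1 to compound 2 (0.25 log units; within the scatter), is within the scatter. Compound 3 `C[C@@H]1CN(c2sc(Br)nc2-c2nc3ccccc3[nH]2)CCN1C(=O)Cn1cnc2cccnc21` carries bromo in place of cyclopropyl on an aromatic carbon, on an aromatic carbon of a five-membered aromatic ring with one nitrogen and one sulfur, next to the ring nitrogen and next to the ring sulfur. Going by the values given here, the one step that bears on this position, from hydrogen to cyclopropyl, did not move the number beyond the scatter, so no step beyond the scatter is expected here either, in either direction. Compound 3 is therefore estimated at 750 nM in this assay, with a range of 300 nM to 1800 nM. That estimate means an expected step of a 1.3-fold lower number from compound 2 to compound 3 (0.12 log units; within the scatter).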

Compound 3, half-maximal inhibitory concentration: 526 nM
For compound 3 the middle estimate is 1.4-fold (0.15 log units) above the measured one; the measured number falls inside the stated range.
By their numbers in this assay, from the lowest: compounds 3, 1 and 2 (each within the scatter of the next).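

In this assay, the carbon next to the ring nitrogen and the ring sulfur now carries hydrogen, cyclopropyl or bromo, and the two new steps both stay within the scatter (a 1.9-fold lower number from compound 2 to compound 3 (0.28 log units; within the scatter); a 1.1-fold lower number from compound 1 to compound 3 (0.02 log units; within the scatter)). The earlier pair tested only cyclopropyl against hydrogen; compound 3 adds a single halogen atom with no ring, and the number still shows no step beyond the scatter among the three compounds. No measurement is available that could explain this flat result.

Neither cyclopropyl nor bromo has a hydrogen-bond donor or acceptor, so these compounds do not show how a group bearing either would behave here. Going by these compounds, it remains open whether an amine, a carboxylic acid or a longer alkyl chain on this carbon would give a step beyond the scatter.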